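The source may report more compounds than this note shows. Statements on the series, on what has been measured and on what is new or still open speak of the compounds shown alone.

Measured compounds:
- compound 1 `Cc1ccc(-n2cc(CN3C(=O)C[C@@H]4CC[C@@]3(C)C4(C)C)nn2)cc1`: 40 nM
- compound 2 `CC1(C)[C@H]2CC[C@]1(C)N(Cc1cn(-c3ccccc3)nn1)C(=O)C2`: 50 nM
- compound 3 `CC1(C)[C@H]2CC[C@]1(C)N(Cc1cn(-c3ccc(Br)cc3)nn1)C(=O)C2`: 140 nM

All three share a core and differ only in the group on the phenyl ring attached to the triazole. In a functional assay on OVCAR-3 cells (Homo sapiens) for inhibition, read by MTT assay, with a stated time of 24 h (on this read-out lower numbers stand for stronger inhibition and higher numbers for weaker inhibition), compound 1 gives 40 nM and compound 2 gives 50 nM; the two lie within the scatter of each other, as a 1.3-fold higher number from compound 1 to compound 2 (0.10 log units; within the scatter) shows. Compound 3 stands apart: with 140 nM it has the highest number of the three, a 2.8-fold higher number from compound 2 to compound 3 (0.45 log units; beyond the scatter) and a 3.5-fold higher number from compound 1 to compound 3 (0.54 log units; beyond the scatter) both being modest steps beyond the scatter.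

Compound 4 `CC1(C)[C@H]2CC[C@]1(C)N(Cc1cn(-c3ccc(O)cc3)nn1)C(=O)C2` follows from compound 3 by hydroxy in place of bromo on an aromatic carbon. Among the compounds with values here, no measured pair in this set carries a hydroxy group, so the step has no direct precedent. What the data do show is that the bromo group alone separates compound 3 from compound 2, and that removing it, as in a 2.8-fold higher number from compound 2 to compound 3 (0.45 log units; beyond the scatter) read backwards, brings the number down by a modest amount. Compound 4 is therefore expected to move in that direction, back toward compound 2, with a 2.0-fold lower number from compound 3 to compound 4 (0.30 log units; within the scatter) as the estimated step, though the uncertainty is wide. Compound 4 is estimated at 70 nM in this assay, with a range from 25 nM to 200 nM.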

Compound 4, half-maximal inhibitory concentration: 410 nM
Estimate against measurement, compound 4: 5.9-fold (0.77 log units) below; measured number outside the range, above it.
By their numbers in this assay, from the lowest: compounds 1 and 2 (each within the scatter of the next); then compound 3; then compound 4.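

In this assay, the change from 4-bromophenyl to 4-hydroxyphenyl does not bring the number back toward that of the plain phenyl compound but carries it further away (a 2.9-fold higher number from compound 3 to compound 4 (0.47 log units; beyond the scatter)), so the order at this place, on an aromatic carbon para to a large group, is not set by the loss of bromo alone. Within the data shown here, until now the only step beyond the scatter at this place came from bromo, while methyl and hydrogen stayed within the scatter of each other; hydroxy now gives the widest separations in the set, both against hydrogen (an 8.2-fold higher number from compound 2 to compound 4 (0.91 log units; beyond the scatter)) and against methyl (a 10-fold higher number from compound 1 to compound 4 (1.01 log units; beyond the scatter)), the last of them a large step. The position therefore responds strongly to which single atom is attached there, and nothing available here accounts for why hydroxy has this effect.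

The compounds shown leave open whether a methoxy group or an amine on the same carbon would fall with hydroxy or with methyl and hydrogen. They also leave open whether a chloro or fluoro group would follow bromo.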